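Swapping an aryl amide for a cyclohexyl amide

A few compounds are considered here, and "the series" means these few. Any claim that something is new, unique, unknown or untested is made for them only; others in the source may bear on it.

Measured compounds:
- compound 1, `Cc1cc(C)cc(NC(=O)CN2CCC(c3cccc[n+]3[O-])CC2)c1`: 76%
- compound 2, `Cc1cc(NC(=O)CN2CCC(c3cccc[n+]3[O-])CC2)ccc1F`: 75%
- compound 3, `CSc1cccc(NC(=O)CN2CCC(c3cccc[n+]3[O-])CC2)c1`: 56%

In a functional assay on HEK293 cells for agonist activity at D(4) dopamine receptor (Homo sapiens), read by FLIPR (a lower number here means a smaller maximal response, a higher number a larger maximal response), compound 3 gives the lowest of the three numbers. Its nearest neighbour is compound 2, reached by a number 19 percentage points lower from compound 2 to compound 3 (beyond the scatter), and the furthest is compound 1, reached by a number 20 percentage points lower from compound 1 to compound 3 (beyond the scatter). The step of a number 1 percentage points lower from compound 1 to compound 2 (within the scatter) shows that one aryl exchange left the read-out essentially unchanged, while the exchanges leading to compound 3 lowered it modestly.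

Compound 4, `O=C(CN1CCC(c2cccc[n+]2[O-])CC1)NC1CCCCC1`, is not yet measured. It differs from compound 3 in this way: cyclohexyl in place of 3-(methylsulfanyl)phenyl on an amide-type nitrogen. Within the data shown here, none of the measured steps replaces an aromatic group with a non-aromatic ring on the amide-type nitrogen, so the three steps bear on it only indirectly: they show that changes at this position have shifted this assay by nothing beyond the scatter or by a modest amount. With this in mind, compound 4 is expected to give a read-out of 58%, within 35% to 82%. This estimate means a step of a number 2 percentage points higher from compound 3 to compound 4 (within the scatter), which is expected to stay within the scatter, with wide uncertainty.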

Compound 4, largest response reached (reported as efficacy), in percent of the reference or control that the assay uses: 58%
Beside the measured number, compound 4's estimate shows no gap at the digits printed; low and high end bracket the measured number.
By their numbers in this assay, from the lowest: compounds 3 and 4 (each within the scatter of the next); then compounds 2 and 1 (each within the scatter of the next).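

In this assay, an aromatic ring on the amide-type nitrogen proves not to be required for this level of response: with cyclohexyl in place of 3-(methylsulfanyl)phenyl, the comparison gives a number 2 percentage points higher from compound 3 to compound 4 (within the scatter) and so offers no sign that the loss of aromaticity matters against that aryl group. The same ring measured against the other two aryl groups gives a number 17 percentage points lower from compound 2 to compound 4 (beyond the scatter) and a number 18 percentage points lower from compound 1 to compound 4 (beyond the scatter), so the answer depends on which aryl group is exchanged, and 3-(methylsulfanyl)phenyl groups with cyclohexyl, not with 4-fluoro-3-methylphenyl or 3,5-dimethylphenyl. Nothing in the data gives a reason for this grouping.

Still open, as far as these compounds go, is whether a smaller ring such as cyclopentyl or an open chain such as n-butyl would fall with cyclohexyl. Equally open, from the compounds shown here alone, is what a hydroxyl group or an amine on the cyclohexyl ring would do to the response.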